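Two Inactive Amides and a Dimethylphenyl Variant

The compounds below may be only part of what the source reports. "The series", "measured", "known", "first", "only" and "open" are said of these compounds alone.

Measured compounds:
- Compound 1, `CC(C)n1ncc2c(C(=O)Nc3cccnc3)cccc21`, in a functional assay on HepG2 cells (Homo sapiens) for inhibition, read by MTT assay, with a stated time of 72 h (on this read-out higher numbers stand for weaker inhibition and lower numbers for stronger inhibition), gives the limit > 40000 nM.
- Compound 2, `CC(C)n1ncc2c(C(=O)NCc3cn(-c4ccccc4)nn3)cccc21`, in this assay gives the limit > 40000 nM.

Both values are limits of the assay, not numbers. Going by the values given here, compound 2 therefore stands at the limit rather than at a measured point; both compounds sit there, as the limit of > 40000 nM in this assay, at which 2 of the 2 values shown sit, shows, so no ordering between them can be read from what is known, and no measured step between them exists.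

Compound 3, `Cc1ccc(-n2cc(CNC(=O)c3cccc4c3cnn4C(C)C)nn2)cc1C`, is not yet measured. It differs from compound 2 in one place: 3,4-dimethylphenyl in place of phenyl on an aromatic nitrogen. Because compound 2 is known only as the limit > 40000 nM, there is no measured change of this kind to lean on, and the expectation for the step from compound 2 to compound 3 is none beyond the scatter, with the result most likely again reported as a limit. The expected step is a step that the limit leaves unreadable from compound 2 to compound 3. Compound 3 is accordingly estimated at 50000 nM, with a range from 15000 nM to 200000 nM, in this assay.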

Compound 3, half-maximal inhibitory concentration: > 40000 nM
Compound 3 ended at the assay's limit; the forecaster's own chance of this, stated with the estimate: 80%; the middle value is on the limit's open side.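

In this assay compound 3 gives > 40000 nM, which is a limit of the assay and not a number. No step from compound 2 to compound 3 can therefore be read, as both stand at the same limit: the limit of > 40000 nM in this assay, at which 3 of the 3 values shown sit.

The compounds shown leave open whether any change to the shared core or its amide side chain would give a measurable value in this assay.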